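A few compounds are considered here, and "the series" means these few. Any claim that something is new, unique, unknown or untested is made for them only; others in the source may bear on it.

Compounds measured so far in a functional assay on SN12C cells (Homo sapiens) for inhibition, read by sulforhodamine B assay, with a stated time of 48 h, tested at 10 uM; a higher number here means more inhibition at the concentration tested (going by the name of the read-out), a lower number less inhibition:

compound 1, `c1ccc(-c2cn3ccnc3c(-c3ccc4ncn(C5CCCCC5)c4c3)n2)cc1`, 28.8%
compound 2, `Brc1ccc(-c2cn3ccnc3c(-c3ccc4ncn(C5CCCCC5)c4c3)n2)cc1`, 18.4%
compound 3, `c1csc(-c2cn3ccnc3c(-c3ccc4ncn(C5CCCCC5)c4c3)n2)c1`, 2.84%

Compound 3 stands lowest of the three, the nearest being compound 2 and the furthest compound 1; both gaps lie beyond the scatter. The next compound, compound 4 `FC(F)(F)c1cccc(-c2cn3ccnc3c(-c3ccc4ncn(C5CCCCC5)c4c3)n2)c1`, is not yet measured. Its change from compound 3 is 3-(trifluoromethyl)phenyl in place of thiophen-2-yl on an aromatic carbon.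

Among the compounds with values here, two measured steps bear on this change, both reaching the same thiophen-2-yl end point: a number 26 percentage points lower from compound 1 to compound 3 (beyond the scatter) and a number 15.6 percentage points lower from compound 2 to compound 3 (beyond the scatter). Reversing the direction, a six-membered carbon ring in place of thiophen-2-yl is therefore expected to raise inhibition. Among the two carbon rings measured, the substituted one, compound 2, sits lower than the unsubstituted compound 1 by a number 10.4 percentage points lower from compound 1 to compound 2 (beyond the scatter), so a substituted ring is expected to land nearer compound 2 than compound 1.

For compound 4 the expected step is a number 17.2 percentage points higher from compound 3 to compound 4 (beyond the scatter), giving an estimated 20%, within 6% to 34%.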

Compound 4, a percentage reported as inhibition, at one concentration (the size of the read-out at that concentration, not a potency): 8.3%
For compound 4 the middle estimate is 11.7 percentage points above the measured one; the range from low to high includes it.
By their numbers in this assay, from the lowest: compounds 3 and 4 (each within the scatter of the next); then compound 2; then compound 1.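

In this assay the swap of thiophen-2-yl for 3-(trifluoromethyl)phenyl gives a number 5.5 percentage points higher from compound 3 to compound 4 (within the scatter) so a six-membered carbon ring alone brings no gain at this position. Adding trifluoromethyl to the phenyl ring gives a number 20.5 percentage points lower from compound 1 to compound 4 (beyond the scatter) and the 3-(trifluoromethyl)phenyl group also trails 4-bromophenyl, with a number 10.1 percentage points lower from compound 2 to compound 4 (beyond the scatter) so neither substituent shown improves on plain phenyl. No measurement at hand explains these steps.

Whether the substituent or its place on the ring sets the value stays open, as 4-(trifluoromethyl)phenyl and 3-bromophenyl are not among the compounds shown. Going by these compounds, how an amine or a carboxylic acid on the phenyl ring would read is also open.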